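A Nitro Group Added to an Inactive Pair

The compounds below may be only part of what the source reports. "The series", "measured", "known", "first", "only" and "open" are said of these compounds alone.

Compound 1, `Cc1ccc(-c2cn3nc(Cc4ccc(Cl)cc4)sc3n2)cc1`: in an ADME assay on CCRF-CEM cells (Homo sapiens) for cytotoxicity, with a stated time of 72 h (on this read-out higher numbers stand for weaker inhibition and lower numbers for stronger inhibition), compound 1 gives only the limit > 250000 nM.
Compound 2, `Clc1ccc(Cc2nn3cc(-c4ccccc4)nc3s2)cc1`: in this assay compound 2 gives only the limit > 250000 nM.

Compound 2 therefore stands at a limit of the assay, not at a measured number, and the same holds for compound 1. Among the measured compounds shown here, the single measured step, a step that the two limits leave unreadable from compound 1 to compound 2, has no readable size, because both of its ends sit at the limit of > 250000 nM in this assay, at which 2 of the 2 values shown sit. Compound 3, `O=[N+]([O-])c1ccc(-c2cn3nc(Cc4ccc(Cl)cc4)sc3n2)cc1`, departs from compound 2 by nitro in place of hydrogen on an aromatic carbon. For the measured compounds named here, no measured step involves a nitro group, and the only step available gives no size at all, so there is nothing in the numbers that would point to a gain or loss in this assay beyond the scatter. With both neighbours at the limit, compound 3 is expected to show a step of a number no higher from compound 2 to compound 3 (the limit leaves the size open), that is, no readable change. Compound 3 is accordingly estimated at 250000 nM, with a range from 40000 nM to 1000000 nM, and most likely the assay will again report only a limit for compound 3.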

Compound 3, half-maximal inhibitory concentration: > 250000 nM
Compound 3 was reported as a limit (the forecaster's own chance of this, stated with the estimate: 80%); the middle value sits exactly at the limit.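

Among the compounds shown here, compound 3 joins compound 1 and compound 2 at the same limit, so no new step can be read, neither the one from compound 2 nor the one from compound 1: the limit of > 250000 nM in this assay, at which 3 of the 3 values shown sit. The compounds shown leave open whether in this assay nitro, methyl or hydrogen on the aromatic carbon makes any difference at all.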